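Thiazolinone in place of phenylthiazoline on compound 2

The source may report more compounds than this note shows. Statements on the series, on what has been measured and on what is new or still open speak of the compounds shown alone.

Measured so far in a functional assay on BGC-823 cells (Homo sapiens) for inhibition, read by CCK-8 assay, with a stated time of 48 h; a lower number here means a stronger inhibitor, a higher number a weaker inhibitor:
compound 1 `Brc1ccc(C2=NN(C3=NC(c4ccccc4)CS3)C(c3ccc4ccccc4c3)C2)cc1` gives 13000 nM
compound 2 `Fc1ccc(C2=NN(C3=NC(c4ccccc4)CS3)C(c3cccc4ccccc34)C2)cc1` gives 22700 nM
compound 3 `Clc1ccc(C2=NN(C3=NC(c4ccccc4)CS3)C(c3ccc4ccccc4c3)C2)cc1` gives 14600 nM

Compound 2 stands at the highest of the three numbers in this assay, but the gaps to compound 3 and to compound 1 are both within the scatter, so the three cannot be separated. Among the compounds with values here, the only step between measured compounds is a 1.1-fold higher number from compound 1 to compound 3 (0.05 log units; within the scatter), a halogen swap on the aromatic ring; it says nothing about the nitrogen-bound ring.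

Compound 4 `O=C1CSC(N2N=C(c3ccc(F)cc3)CC2c2cccc3ccccc23)=N1` differs from compound 2 by a group of 6 heavy atoms (3 carbon, 1 nitrogen, 1 oxygen, 1 sulfur; one five-membered non-aromatic ring with 2 hetero atoms) in place of a group of 11 heavy atoms (9 carbon, 1 nitrogen, 1 sulfur; one five-membered non-aromatic ring with 2 hetero atoms, one six-membered aromatic ring of carbon only), on an amine nitrogen in a ring. Within the data shown here, no measured pair touches this position, so there is no step to lean on; the expectation rests only on the tight cluster of compound 1, compound 2 and compound 3.

Compound 4 is therefore expected to stay near compound 2, with a 1.1-fold higher number from compound 2 to compound 4 (0.04 log units; within the scatter) as the expected step, no direction preferred. The estimate for compound 4 in this assay is 25000 nM, expected between 8000 nM and 80000 nM, with the range kept wide.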

Compound 4, half-maximal inhibitory concentration: 19300 nM
Compound 4: the middle estimate sits 1.3-fold (0.11 log units) above what was measured; the measured number falls inside the stated range.
By their numbers in this assay, from the lowest: compounds 1, 3, 4 and 2 (each within the scatter of the next).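

The exchange on the amine nitrogen in a ring gives a 1.2-fold lower number from compound 2 to compound 4 (0.07 log units; within the scatter) in this assay, the first step read at this position. In this single pair, the six-membered aromatic ring of carbon only can leave with the larger group, and the read-out stays within the scatter, so that ring is not required to hold the number at this level. No measurement available here bears on this result.

As far as these compounds go, both groups compared on this nitrogen contain a five-membered non-aromatic ring with hetero atoms, so it remains open whether an open-chain group, such as an acetyl group or a carboxylic acid, would move the number beyond the scatter. From the compounds shown here alone, whether the same exchange reads alike on the cores of compound 1 and compound 3 also remains open.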